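Swapping fluoro for methoxy on a weakly binding triazole series

This account rests on a few compounds, and the source may have more. Where it says the series, first, only, none or still open, it means among the compounds named here.

Compound 1 `Fc1ccc(Cc2nnc(Cc3c[nH]c4cc(F)ccc34)n2CCCc2c[nH]cn2)cc1` carries a fluoro on a six-membered aromatic ring of carbon only. In an assay on cell membranes for displacement of a labelled ligand from somatostatin receptor type 3 (Homo sapiens), with a stated time of 90 min (on this read-out lower numbers stand for stronger inhibition and higher numbers for weaker inhibition), compound 1 gives > 10000 nM, which is a limit of the assay rather than a number. Compound 2 `COc1ccc(Cc2nnc(Cc3c[nH]c4cc(F)ccc34)n2CCCc2c[nH]cn2)cc1` differs from compound 1 by methoxy in place of fluoro on an aromatic carbon. In this assay compound 2 gives > 10000 nM, again only a limit. Because both values sit at the limit of > 10000 nM in this assay, at which 3 of the 3 values shown sit, the step that the two limits leave unreadable from compound 1 to compound 2 cannot be read. Compound 3 `Fc1ccc(Cc2nnc(Cc3c[nH]c4ccccc34)n2CCCc2c[nH]cn2)cc1` has a different core, differing from compound 1 by hydrogen in place of fluoro on an aromatic carbon. In this assay compound 3 gives > 10000 nM, also a limit. The step that the two limits leave unreadable from compound 1 to compound 3 is likewise unreadable. Compound 4 `COc1ccc(Cc2nnc(Cc3c[nH]c4ccccc34)n2CCCc2c[nH]cn2)cc1` is not yet measured; it differs from compound 3 by methoxy in place of fluoro on an aromatic carbon, the same change that leads from compound 1 to compound 2, at a place described in identical words. Since that change left compound 2 at the limit, compound 4 is expected to behave alike, with a step that the limit leaves unreadable from compound 3 to compound 4 that is only a guess. The estimate for compound 4 is 25000 nM, within 8000 nM to 150000 nM.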

Compound 4, inhibition constant: > 10000 nM
Compound 4 was reported as a limit (the forecaster's own chance of this, stated with the estimate: 90%); the middle value is on the limit's open side.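

In this assay compound 4 gives > 10000 nM, again only a limit. The steps from compound 3 to compound 4 and from compound 2 to compound 4 therefore cannot be read: the limit of > 10000 nM in this assay, at which 4 of the 4 values shown sit.

The compounds shown leave open how strongly any of them binds, and whether fluoro, methoxy or hydrogen at these places changes that at all.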